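The source may report more compounds than this note shows. Statements on the series, on what has been measured and on what is new or still open speak of the compounds shown alone.

Measured so far in a functional assay on HL-60 cells (Homo sapiens) for cytotoxicity, read by MTT assay, with a stated time of 72 h; a lower number here means a stronger inhibitor, a higher number a weaker inhibitor:

compound 1 `CC(=O)c1ccc(/N=C2\C=C(OCc3cn(S(=O)(=O)c4ccc(C)cc4)nn3)C(=O)c3ccccc32)cc1` gives 5300 nM
compound 2 `Cc1ccc(S(=O)(=O)n2cc(COC3=C/C(=N\c4ccc(I)cc4)c4ccccc4C3=O)nn2)cc1` gives 6310 nM
compound 3 `Cc1ccc(S(=O)(=O)n2cc(COC3=C/C(=N\c4ccc(Br)cc4)c4ccccc4C3=O)nn2)cc1` gives 4220 nM

Compound 3 stands within the scatter of both other compounds, so the three values do not separate into an order. The next compound to be tested is compound 4 `Cc1ccc(S(=O)(=O)n2cc(COC3=C/C(=N\c4ccc(Cl)cc4)c4ccccc4C3=O)nn2)cc1`. It carries chloro in place of bromo on an aromatic carbon, para to a large group (chloro in place of bromo on an aromatic carbon), so the 4-bromophenyl of compound 3 becomes 4-chlorophenyl.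

Going by the values given here, the closest precedent is the swap of one halogen for another, a 1.5-fold lower number from compound 2 to compound 3 (0.17 log units; within the scatter). Two further steps at the same position replace acetyl, a 1.2-fold higher number from compound 1 to compound 2 (0.08 log units; within the scatter) and a 1.3-fold lower number from compound 1 to compound 3 (0.10 log units; within the scatter). All three stay within the scatter, so this position has shown little response in this assay across acetyl, iodo and bromo. Among the compounds with values here, no chloro compound has been measured, and the halogen evidence rests on a single pair.

No step beyond the scatter is therefore expected, and no direction can be assigned. The expected change is a 1.1-fold higher number from compound 3 to compound 4 (0.04 log units; within the scatter). The estimated value for compound 4 is 4600 nM, with an expected range from 2600 nM to 8000 nM.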

Compound 4, half-maximal inhibitory concentration: 6920 nM
Compound 4: the middle estimate sits 1.5-fold (0.18 log units) below what was measured; measured number inside the range.
By their numbers in this assay, from the lowest: compounds 3, 1, 2 and 4 (each within the scatter of the next).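

In this assay chloro on this aromatic carbon gives no separation from any of the other three groups: (a 1.6-fold higher number from compound 3 to compound 4 (0.21 log units; within the scatter)), (a 1.1-fold higher number from compound 2 to compound 4 (0.04 log units; within the scatter)) and (a 1.3-fold higher number from compound 1 to compound 4 (0.12 log units; within the scatter)). Going by these compounds alone, the set at this place, para to a large group, now runs to acetyl, iodo, bromo and chloro, and all four compounds lie within the scatter of one another, so the halogens show no order that can be read; the bromo to chloro step is the largest of the steps so far, yet it too stays within the scatter. No measurement bearing on the reason for these small steps is available.

As far as these compounds go, it remains open whether any group on this aromatic carbon moves the number beyond the scatter, for example an amine, a carboxylic acid or a methoxy group. Within the data shown here, it is equally open whether this flat response holds when the shared core changes, as all four compounds carry that core unchanged and differ only in the one group on the aromatic ring.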